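A methyl on the amide-type nitrogen of compound 2

A few compounds are considered here, and "the series" means these few. Any claim that something is new, unique, unknown or untested is made for them only; others in the source may bear on it.

Three compounds share one core and differ in one place, on a saturated chain carbon, where they carry piperidin-1-yl, diethylamino or pyrrolidin-1-yl. In a functional assay on HeLa cells (Homo sapiens) for inhibition (a higher number here means a weaker inhibitor, a lower number a stronger inhibitor), compound 1 `O=C(CC(CC(=O)NC1Cc2ccccc2C1)c1ccc(Cl)cc1)NCCN1CCCCC1` gives 86200 nM, compound 2 `CCN(CC)CCNC(=O)CC(CC(=O)NC1Cc2ccccc2C1)c1ccc(Cl)cc1` gives 50500 nM and compound 3 `O=C(CC(CC(=O)NC1Cc2ccccc2C1)c1ccc(Cl)cc1)NCCN1CCCC1` gives 77300 nM. Compound 2 therefore stands level with the other two, since the measured steps are a 1.7-fold lower number from compound 1 to compound 2 (0.23 log units; within the scatter), a 1.1-fold lower number from compound 1 to compound 3 (0.05 log units; within the scatter) and a 1.5-fold higher number from compound 2 to compound 3 (0.18 log units; within the scatter).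

Compound 4 `CCN(CC)CCNC(=O)CC(CC(=O)N(C)C1Cc2ccccc2C1)c1ccc(Cl)cc1` departs from compound 2 at a different place, with methyl in place of hydrogen on an amide-type nitrogen. None of the three measured steps touches that nitrogen, so they bear on the change only indirectly. They show how little the numbers moved at the other place and say nothing about this one. As far as these compounds go, without a direct precedent, no step beyond the scatter is expected in this assay, and the direction stays open. The expectation therefore starts from compound 2 at 50500 nM, with a wide range. Compound 4 is estimated at 60000 nM, with an expected range from 25000 nM to 140000 nM. This estimate means an expected 1.2-fold higher number from compound 2 to compound 4 (0.07 log units; within the scatter).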

Compound 4, half-maximal inhibitory concentration: 48100 nM
Estimate against measurement, compound 4: 1.2-fold (0.10 log units) above, within the range that was stated.
By their numbers in this assay, from the lowest: compounds 4, 2, 3 and 1 (each within the scatter of the next).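

Methyl in place of the amide hydrogen, on the amide-type nitrogen whose other neighbours are the carbonyl carbon and a saturated ring carbon, gives a 1.0-fold lower number from compound 2 to compound 4 (0.02 log units; within the scatter) in this assay and so adds a first measured step at this place. The earlier compounds shown here varied only the group on the saturated chain carbon, so they could not show that this nitrogen accepts a methyl without the number leaving the scatter, and with this pair, neither of the two places varied has yet given a step beyond it. The data at hand offer no measurement that would account for this outcome.

Still open is whether the step stays this small with ethyl or a longer chain, such as propyl, on the same nitrogen, since methyl is the only group shown there in place of hydrogen. Also open, as far as these compounds go, is whether methyl on this nitrogen gives a similar step when the chain ends in piperidin-1-yl, as in compound 1, or pyrrolidin-1-yl, as in compound 3, rather than diethylamino.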